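Shortening the hydroxamate linker of a urea series

The compounds below may be only part of what the source reports. "The series", "measured", "known", "first", "only" and "open" are said of these compounds alone.

Compound 1, `O=C(Nc1ccc2c(c1)N(Cc1ccc(C(=O)NO)cc1)CC2)Nc1ccc(Cl)c(C(F)(F)F)c1`, gives 3100 nM in a functional assay on PC-3 cells (Homo sapiens) for inhibition, read by sulforhodamine B assay, with a stated time of 48 h; on this read-out higher numbers stand for weaker inhibition and lower numbers for stronger inhibition.
Compound 2, `O=C(Nc1ccc2c(c1)CCCN2c1ccc(C(=O)NO)cc1)Nc1ccc(Cl)c(C(F)(F)F)c1`, gives 3000 nM in this assay.
Compound 3, `O=C(CCCCCC(=O)Nc1ccc(NC(=O)Nc2ccc(Cl)c(C(F)(F)F)c2)cc1)NO`, gives only a limit in this assay, namely > 10000 nM.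

Compound 1 and compound 2 sit within the scatter of each other. Compound 3 is the one compound of the three that reaches (the limit of > 10000 nM in this assay, at which 1 of the 3 values shown sits), so no number is known for it and it stands apart from the other two on the numbers shown.

Compound 4, `O=C(CCCCC(=O)Nc1ccc(NC(=O)Nc2ccc(Cl)c(C(F)(F)F)c2)cc1)NO`, keeps the urea and the diamide of compound 3 and changes only the chain carrying the hydroxamic acid: hydroxycarbamoyl in place of (hydroxycarbamoyl)methyl on a saturated chain carbon, four bonds along the chain from a carbonyl carbon. With no measured step of this kind in the set, the shorter chain gives no ground to expect a move beyond the scatter in either direction; a return to the range of compound 1 and compound 2 would be a guess without support.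

Compound 4 is therefore expected to give about 12000 nM in this assay, with an estimated range from 4000 nM to 30000 nM. The step that the limit leaves unreadable from compound 3 to compound 4 is expected to stay within the scatter, and a limit rather than a number is the more likely report.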

Compound 4, half-maximal inhibitory concentration: > 10000 nM
Compound 4 ended at the assay's limit; the forecaster's own chance of this, stated with the estimate: 60%; the middle value lies beyond the limit too.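

No step can be read between compound 3 and compound 4, since both stand at the same limit of the assay: the limit of > 10000 nM in this assay, at which 2 of the 4 values shown sit.

The compounds shown leave open what number either compound would give, and whether hydroxycarbamoyl in place of (hydroxycarbamoyl)methyl changes inhibition at all.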